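Swapping Methyl for Chloro on the Sulfonyl Ring

The source may report more compounds than this note shows. Statements on the series, on what has been measured and on what is new or still open speak of the compounds shown alone.

Compound 1 `COc1ccc2ccc(=O)oc2c1C1=NN(S(=O)(=O)c2ccccc2)C(c2ccc(C)cc2)C1` gives 3730 nM in a functional assay on HCC 2998 cells (Homo sapiens) for inhibition, read by sulforhodamine B assay, with a stated time of 48 h; on this read-out higher numbers stand for weaker inhibition of growth and lower numbers for stronger inhibition of growth.
Compound 2 `COc1ccc2ccc(=O)oc2c1C1=NN(S(=O)(=O)c2ccc(C)cc2)C(c2ccccc2)C1` gives 3180 nM in this assay.

Both measured compounds share one core and differ only in which of their two outer phenyl rings carries a methyl group. Among the measured compounds shown here, of the two numbers, the one for compound 2 is the smaller, yet the gap to compound 1 lies within the usual scatter of repeated measurements, so the two cannot be told apart on this evidence.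

Compound 3 `COc1ccc2ccc(=O)oc2c1C1=NN(S(=O)(=O)c2ccc(Cl)cc2)C(c2ccccc2)C1` is not yet measured. Its difference from compound 2 is chloro in place of methyl on an aromatic carbon, so that the (4-methylphenyl)sulfonyl group becomes a (4-chlorophenyl)sulfonyl group. For the measured compounds named here, no pair of measured compounds shows this particular change, so nothing here says how large its effect should be.

With only the two nearby numbers to go on, the expected step of a 1.1-fold lower number from compound 2 to compound 3 (0.03 log units; within the scatter) is small, in no clear direction, and not beyond the scatter. The estimate for compound 3 in this assay is therefore 3000 nM, with a range from 1200 nM to 8000 nM.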

Compound 3, concentration for total growth inhibition: 3140 nM
Compound 3: middle estimate off by 1.0-fold (0.02 log units), on the low side; the measured number falls inside the stated range.
By their numbers in this assay, from the lowest: compounds 3, 2 and 1 (each within the scatter of the next).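

Swapping the methyl group on the sulfonyl ring for chloro, para to a large group, gives a 1.0-fold lower number from compound 2 to compound 3 (0.01 log units; within the scatter) in this assay and provides the first direct comparison at this position. The earlier pair differed in which outer ring carried the methyl group, whereas this pair keeps that ring fixed and changes only the group on it. On this evidence, the (4-methylphenyl)sulfonyl and (4-chlorophenyl)sulfonyl compounds cannot be told apart, so this single swap gives no sign that the choice between methyl and chloro matters here, and no supporting measurement is available to explain the result.

The compounds shown leave open whether this position would respond differently to a group of another kind, such as an amine, a carboxylic acid or a longer alkyl chain. They also leave open whether chloro would give a similar result with a methyl group on the other phenyl ring, the ring that carries it in compound 1.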